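The source may hold more compounds than are shown below. What is called first, only, known or untested is meant among the compounds shown, and "the series" means these compounds.

Compound 1 `Cc1ccc(C(=O)Nc2nc(Cl)c3cn(C)nc3n2)cc1` gives > 20000 nM in a functional assay on CHO cells for antagonist activity at adenosine receptor A2b (Homo sapiens), read by 33P incorporation, with a stated time of 20 min, in the presence of a further agent that is not named here; on this read-out lower numbers stand for stronger inhibition and higher numbers for weaker inhibition. Compound 2 `Cc1ccc(C(=O)Nc2nc(Cl)c3cn(CC(C)(C)C)nc3n2)cc1` gives > 10000 nM. Compound 3 `CC(C)n1cc2c(Cl)nc(NC(=O)c3ccccc3)nc2n1` gives > 20000 nM.

All three values are limits of the assay and not numbers. Compound 3 stands at > 20000 nM, which is a limit; two of the three measured compounds sit at the limit of > 20000 nM in this assay, at which 2 of the 3 values shown sit, and one at the limit of > 10000 nM in this assay, at which 1 of the 3 values shown sits. Compound 4 `Cc1ccc(C(=O)Nc2nc(Cl)c3cn(C(C)C)nc3n2)cc1` differs from compound 3 by methyl in place of hydrogen on an aromatic carbon. Among the compounds with values here, the one measured step, a step that the two limits leave unreadable from compound 1 to compound 2, runs between two limits and cannot be read, so no measured step bears on the size of this change. The estimated step of a number no higher from compound 3 to compound 4 (the limit leaves the size open) is therefore expected to be none beyond the scatter. Compound 4 is expected to come out near 20000 nM, in the range 5000 nM to 50000 nM, most likely again reported only as a limit.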

Compound 4, inhibition constant: > 20000 nM
Compound 4 was reported as a limit; the forecaster's own chance of this, stated with the estimate: 85%; the middle value lies on the limit itself.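

The steps from compound 1, compound 2 and compound 3 to compound 4 cannot be read; all four values are limits of the assay. The compounds shown leave open whether the methyl or the groups on the aromatic nitrogen change the inhibition constant at all.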